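Octadecyl amide series: benzoyl to indole-2-carbonyl exchange

The compounds below may be only part of what the source reports. "The series", "measured", "known", "first", "only" and "open" are said of these compounds alone.

The series carries an octyl or octadecyl amide on a shared core. Compound 1 `CCCCCCCCNC(=O)[C@@H](NC(=O)c1ccccc1)[C@@H](C)O` gives 136000 nM in a functional assay on HepG2 cells (Homo sapiens) for cytotoxicity, read by MTT assay, with a stated time of 48 h; on this read-out higher numbers stand for weaker inhibition and lower numbers for stronger inhibition. Compound 2 `CCCCCCCCCCCCCCCCCCNC(=O)[C@@H](NC(=O)c1ccccc1)[C@@H](C)O` reaches only a limit, > 400000 nM, in this assay, and this limit is the limit of > 400000 nM in this assay, at which 1 of the 2 values shown sits. Among the measured compounds shown here, the one measured step, an at least 2.9-fold higher number from compound 1 to compound 2 (0.46 log units; beyond the scatter), concerns the chain alone. Compound 3 `CCCCCCCCCCCCCCCCCCNC(=O)[C@@H](NC(=O)c1cc2ccccc2[nH]1)[C@@H](C)O` differs from compound 2 by 1H-indol-2-yl in place of phenyl on a carbonyl carbon. For the measured compounds named here, no measured step touches this part of the molecule, so the size of the step from compound 2 to compound 3 in this assay has no precedent. Because the value of compound 2 is > 400000 nM, the expected outcome for compound 3 is again a limit rather than a number. The step is expected to be a number no higher from compound 2 to compound 3 (the limit leaves the size open). Compound 3 is estimated at 400000 nM, within 150000 nM to 1000000 nM.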

Compound 3, half-maximal inhibitory concentration: 89400 nM
Beside the measured number, compound 3's estimate is 4.5-fold (0.65 log units) above it, and the stated range ends above it.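

Notes on the acyl side: this position on a carbonyl carbon, untouched by the earlier chain step, proves responsive in this assay, with 1H-indol-2-yl in place of phenyl giving an at least 4.4-fold lower number from compound 2 to compound 3 (0.65 log units; beyond the scatter). The octadecyl amide therefore does not by itself fix the read-out at the top of the range, and a measured number returns on that chain once the acyl group changes. The full size of this step stays open because compound 2 stands at a limit and not at a number: the limit of > 400000 nM in this assay, at which 1 of the 3 values shown sits.

As far as these compounds go, whether the same exchange carries over to the octyl amide remains open, since compound 1 and compound 3 differ in two places and allow no direct comparison. Also open, from the compounds shown here alone, is how a naphthyl or a quinolinyl group would read on the same carbonyl carbon.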